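This account rests on a few compounds, and the source may have more. Where it says the series, first, only, none or still open, it means among the compounds named here.

Measured in a functional assay on HepG2 cells (Homo sapiens) for antiproliferative activity, read by CCK-8 assay, with a stated time of 72 h; on this read-out lower numbers stand for stronger inhibition and higher numbers for weaker inhibition:
Compound 1 `O=C(Nc1cccc(-c2oc3cc(-c4ccc(F)cc4)ccc3c(=O)c2O)c1)c1ccc(Cl)cc1` gives 11000 nM.
Compound 2 `Cc1cccc(C(=O)Nc2cccc(-c3oc4cc(-c5ccc(F)cc5)ccc4c(=O)c3O)c2)c1` gives 13500 nM.
Compound 3 `O=C(Nc1cccc(-c2oc3cc(-c4ccc(F)cc4)ccc3c(=O)c2O)c1)c1cc(F)cc(F)c1` gives 4960 nM.

Compound 2 gives the largest of the three numbers, but the step of a 1.2-fold higher number from compound 1 to compound 2 (0.09 log units; within the scatter) is within the scatter, so compounds 1 and 2 cannot be told apart, while a 2.7-fold lower number from compound 2 to compound 3 (0.43 log units; beyond the scatter) reaches beyond it. Compound 4 `N#Cc1ccc(C(=O)Nc2cccc(-c3oc4cc(-c5ccc(F)cc5)ccc4c(=O)c3O)c2)cc1` is not yet measured; it differs from compound 2 by 4-cyanophenyl in place of 3-methylphenyl on a carbonyl carbon. For the measured compounds named here, the steps that bear on this are the exchanges on the same carbonyl carbon, a 1.2-fold higher number from compound 1 to compound 2 (0.09 log units; within the scatter) and a 2.7-fold lower number from compound 2 to compound 3 (0.43 log units; beyond the scatter), both small to modest. Going by the values given here, no measured compound carries the 4-cyanophenyl, so the expectation rests on those two. A modest lowering is expected, about a 1.5-fold lower number from compound 2 to compound 4 (0.18 log units; within the scatter). Compound 4 is estimated at 9000 nM, within a range from 3500 nM to 22000 nM.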

Compound 4, half-maximal inhibitory concentration: 7110 nM
Compound 4: the middle estimate sits 1.3-fold (0.10 log units) above what was measured; low and high end bracket the measured number.
By their numbers in this assay, from the lowest: compounds 3, 4, 1 and 2 (each within the scatter of the next, the first and the last beyond it).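

In this assay the 4-cyanophenyl on this carbonyl carbon cannot be told apart from any of the three groups measured before it (a 1.9-fold lower number from compound 2 to compound 4 (0.28 log units; within the scatter)) (a 1.4-fold higher number from compound 3 to compound 4 (0.16 log units; within the scatter)) (a 1.5-fold lower number from compound 1 to compound 4 (0.19 log units; within the scatter)). The last of these steps is the plain exchange of cyano for chloro on an aromatic carbon, and it too stays within the scatter. Compound 4 thus lies within the scatter of both compound 2 and compound 3, although those two lie beyond it from each other, and no measurement here offers an explanation.

Still open, from the compounds shown here alone, is whether a carboxylic acid or an amine on this phenyl ring would move the number beyond the scatter. Equally open, going by these compounds, is what a cyclohexyl in place of the phenyl ring would do.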